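Chloro in Place of Nitro: Expectation for Compound 3

The compounds below may be only part of what the source reports. "The series", "measured", "known", "first", "only" and "open" are said of these compounds alone.

Of the compounds shown here, two of the shared core have been measured. Compound 1 `Clc1ccc(Cn2cc(COc3ccccc3)nn2)cc1` was tested in an ADME assay on PANC-1 cells (Homo sapiens) for inhibition, read by MTT assay, with a stated time of 48 h (a higher number here means a weaker inhibitor of growth, a lower number a stronger inhibitor of growth), and for compound 1 the result is only a limit, > 100 ug/mL. Compound 2 `O=[N+]([O-])c1ccc(Cn2cc(COc3ccc(Cl)cc3)nn2)cc1` likewise gives only a limit in this assay, namely > 100 ug/mL. Where compound 2 stands is therefore not a number: both values shown sit at the limit of > 100 ug/mL in this assay, at which 2 of the 2 values shown sit, so no step between measured compounds can be drawn. Compound 3 `Clc1ccc(Cn2cc(COc3ccc(Cl)cc3)nn2)cc1` has not yet been measured. It differs from compound 2 by chloro in place of nitro on an aromatic carbon. Because compound 2 sits at the limit of > 100 ug/mL in this assay, at which 2 of the 2 values shown sit, no direction for the change can be read from the data. The step expected from this change, a step that the limit leaves unreadable from compound 2 to compound 3, is none beyond the scatter. Compound 3 is accordingly expected to give about 150 ug/mL in this assay, within a range of 50 ug/mL to 450 ug/mL.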

Compound 3, concentration for 50% growth inhibition: > 100 ug/mL
Compound 3: a limit, no number (the forecaster's own chance of this, stated with the estimate: 85%); the middle value does not contradict the limit.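

No step can be read from compound 1 or compound 2 to compound 3, because all three compounds give only a limit: the limit of > 100 ug/mL in this assay, at which 3 of the 3 values shown sit.

The compounds shown leave open how far each lies from that limit, and whether any change on the shared core shifts the result in this assay.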